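A few compounds are considered here, and "the series" means these few. Any claim that something is new, unique, unknown or untested is made for them only; others in the source may bear on it.

Measured in a functional assay on SW-620 cells (Homo sapiens) for cytotoxicity, read by MTT assay, with a stated time of 72 h; on this read-out lower numbers stand for stronger inhibition and higher numbers for weaker inhibition:
compound 1 `COc1cccc(/C=C2\CCC/C(=C\c3cccc(Br)c3)C2=O)c1OC`: 8800 nM
compound 2 `COc1cccc(/C=C2\CCC/C(=C\c3ccc(Cl)c(Cl)c3)C2=O)c1OC`: 10000 nM

Only these two compounds have been measured, so the record is short. Compound 2 gives 10000 nM, and its nearest and only neighbour is compound 1 at 8800 nM. Among the measured compounds shown here, the one measured step, a 1.1-fold higher number from compound 1 to compound 2 (0.06 log units; within the scatter), does not separate the two, so neither can be ranked above the other.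

The next compound is compound 3 `COc1cc(/C=C2\CCC/C(=C\c3cccc(OC)c3OC)C2=O)ccc1O`, which keeps the shared core and changes one aryl group: 4-hydroxy-3-methoxyphenyl in place of 3,4-dichlorophenyl on a double-bonded chain carbon bound to a double-bonded ring carbon. This is a larger change than the measured one, which exchanged 3-bromophenyl for 3,4-dichlorophenyl. For the measured compounds named here, the entering 4-hydroxy-3-methoxyphenyl has no measured precedent here, so that step of a 1.1-fold higher number from compound 1 to compound 2 (0.06 log units; within the scatter) only weakly guides the expectation, and the data give no firm direction. No step beyond the scatter is therefore expected, though the uncertainty is wide. The expected change is a 1.4-fold lower number from compound 2 to compound 3 (0.15 log units; within the scatter). In this assay, the estimated value for compound 3 is 7000 nM, with an expected range from 2500 nM to 20000 nM.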

Compound 3, half-maximal inhibitory concentration: 8600 nM
Beside the measured number, compound 3's estimate is 1.2-fold (0.09 log units) below it; low and high end bracket the measured number.
By their numbers in this assay, from the lowest: compounds 3, 1 and 2 (each within the scatter of the next).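

In this assay, placing 4-hydroxy-3-methoxyphenyl on a double-bonded chain carbon bound to a double-bonded ring carbon gives a 1.2-fold lower number from compound 2 to compound 3 (0.07 log units; within the scatter) and a 1.0-fold lower number from compound 1 to compound 3 (0.01 log units; within the scatter). Among the compounds shown here, the earlier pair had compared only two halogen-bearing aryl groups, whereas this result shows that an entering group with a hydrogen-bond donor and hydrogen-bond acceptors, replacing a 3,4-dichlorophenyl group that has neither, still cannot be told apart from them at this position. Nothing available explains why the three numbers stay so close together.

The compounds shown therefore set no direction for this position, and all three sit in the same narrow band of this assay, so no aryl group can be preferred over another. Going by these compounds, it remains open whether a different kind of group here, such as an amine or a carboxylic acid, would give a step beyond the scatter, and whether altering the second aryl group, held constant across these compounds, would do so.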